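Heteroaryl ketones on the enone carbonyl of the series

The source may report more compounds than this note shows. Statements on the series, on what has been measured and on what is new or still open speak of the compounds shown alone.

Compound 3 `COc1ccc(-c2cc3ccccc3nc2/C=C/C(=O)c2sccc2N)cc1` sits at the lowest rung shown: in a functional assay on SK-BR-3 cells (Homo sapiens) for antiproliferative activity, read by XTT assay, with a stated time of 72 h (a higher number here means a weaker inhibitor, a lower number a stronger inhibitor), compound 3 gives only a limit, > 10000 nM. Compound 1 `COc1ccc(-c2cc3ccccc3nc2/C=C/C(=O)c2c(OC)cccc2OC)cc1` gives 3830 nM in this assay. Compound 2 `COc1ccc(-c2cc3ccccc3nc2/C=C/C(=O)c2ccc[nH]2)cc1` gives only a limit, > 10000 nM. Compound 4 `COc1ccc(-c2cc3ccccc3nc2/C=C/C(=O)c2cnc(N)nc2C)cc1` differs from compound 3 in one place: 2-amino-4-methylpyrimidin-5-yl in place of 3-aminothiophen-2-yl on a carbonyl carbon. Within the data shown here, the steps that bear on it are an at least 2.6-fold higher number from compound 1 to compound 3 (0.41 log units; beyond the scatter) and a step that the two limits leave unreadable from compound 2 to compound 3; the aminomethylpyrimidine carbonyl itself is untested, and the limit of > 10000 nM in this assay, at which 2 of the 3 values shown sit, caps what the existing heteroaryl ketones show. No step beyond the scatter is readable from compound 3, so compound 4 is expected to stay near the limit, a number no higher from compound 3 to compound 4 (the limit leaves the size open). The estimate for compound 4 is 10000 nM, within 3000 nM to 30000 nM.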

Compound 4, half-maximal inhibitory concentration: > 10000 nM
Compound 4 ended at the assay's limit (the forecaster's own chance of this, stated with the estimate: 55%); the middle value sits exactly at the limit.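

On the carbonyl carbon in this assay, the six-membered 2-amino-4-methylpyrimidin-5-yl gives an at least 2.6-fold higher number from compound 1 to compound 4 (0.41 log units; beyond the scatter), so replacing 2,6-dimethoxyphenyl now reads the same way for a six-membered aromatic ring as for the two five-membered ones. The steps to compound 4 from compound 2 and from compound 3 cannot be read, as both ends of each are limits. The heteroaryl ketones now gather at one point: the limit of > 10000 nM in this assay, at which 3 of the 4 values shown sit.

Any order among the heteroaryl ketones stays open. Also open, on these data alone, is whether the methoxy groups of compound 1 matter, which an unsubstituted phenyl or a 2-methoxyphenyl on the carbonyl would test.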